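Working notes: methoxy in place of fluoro

The compounds below may be only part of what the source reports. "The series", "measured", "known", "first", "only" and "open" are said of these compounds alone.

Measured in an ADME assay on HepG2 cells (Homo sapiens) for cytotoxicity, read by MTT assay, with a stated time of 72 h; a higher number here means that more compound is tolerated, a lower number that less compound is tolerated:
- compound 1 `COc1ccc(-c2cc3nc(NC(C)(C)C)[nH]c(=O)c3s2)cc1`: 32300 nM
- compound 2 `CC(C)Nc1nc2cc(-c3ccc(Br)cc3)sc2c(=O)[nH]1`: 13400 nM
- compound 3 `CC(C)Nc1nc2cc(-c3ccc(F)cc3)sc2c(=O)[nH]1`: > 25000 nM (a limit, not a number)

Compound 3 gives > 25000 nM, which is a limit of the assay and not a number. This is the limit of > 25000 nM in this assay, at which 1 of the 3 values shown sits.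

Compound 4 `COc1ccc(-c2cc3nc(NC(C)C)[nH]c(=O)c3s2)cc1` differs from compound 3 by methoxy in place of fluoro on an aromatic carbon.

Among the measured compounds shown here, one measured step bears on this place in the structure. It is an at least 1.8-fold higher number from compound 2 to compound 3 (0.27 log units; that floor lies within the scatter), with fluoro in place of bromo on an aromatic carbon, and its floor stays within the scatter. For the measured compounds named here, compound 1 already carries methoxy at this place and gives 32300 nM, though no measured step connects it to compound 4. With compound 1 at 32300 nM, no step beyond the scatter is expected in this assay, in either direction. The expected step is an at least 1.0-fold lower number from compound 3 to compound 4 (0.01 log units; that floor lies within the scatter). Going by the values given here, a reading at the limit would also be no surprise for this compound.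

For compound 4 the estimate is 24000 nM, with an expected range from 11000 nM to 50000 nM.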

Compound 4, half-maximal cytotoxic concentration: 27100 nM
The estimate for compound 4 lay 1.1-fold (0.05 log units) below the measured number, and the stated range covers the measured number.
By their numbers in this assay, from the lowest: compound 2; then compounds 4 and 1 (each within the scatter of the next).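

In this assay, the change from fluoro to methoxy cannot be read, since the value of compound 3 is a limit and not a number: the limit of > 25000 nM in this assay, at which 1 of the 4 values shown sits.

The same place still yields one readable comparison, with methoxy in place of bromo on the aromatic carbon giving a 2.0-fold higher number from compound 2 to compound 4 (0.31 log units; beyond the scatter), a modest step that shows this position can move the number in this assay when the halogen leaving is bromo. On the other side of the molecule, with methoxy held constant, hydrogen in place of methyl on the saturated chain carbon bound to the nitrogen gives a 1.2-fold lower number from compound 1 to compound 4 (0.08 log units; within the scatter), so that change shows no effect that can be told from the scatter.

The compounds shown carry only bromo, fluoro and methoxy at the aromatic carbon, which leaves open how an amine or a carboxylic acid at this place would read in this assay. On these data alone, on the saturated chain, a longer chain or a ring-bearing group remains open, as does the size of any difference between fluoro and methoxy.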